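The compounds below may be only part of what the source reports. "The series", "measured", "known", "first", "only" and "open" are said of these compounds alone.

Working notes on the series. Compound 1, `COc1cc(NCc2ccccc2)cc(OC)c1OC`, is the starting point of the shared core. In a functional assay on HCT-116 cells (Homo sapiens) for inhibition, read by MTT assay, with a stated time of 48 h (on this read-out lower numbers stand for stronger inhibition and higher numbers for weaker inhibition), compound 1 gives only a limit, > 80000 nM, which is the limit of > 80000 nM in this assay, at which 1 of the 2 values shown sits. For the measured compounds named here, compound 2, `COc1ccc(CN(C(C)=O)c2cc(OC)c(OC)c(OC)c2)cc1O`, is the only compound of the pair with a number rather than a limit: in this assay compound 2 gives 270 nM. Compound 3, `COc1ccc(CN(C(=O)CO)c2cc(OC)c(OC)c(OC)c2)cc1O`, has not yet been tested in this assay. It differs from compound 2 by hydroxy in place of hydrogen on a saturated chain carbon bound to a carbonyl carbon. Going by the values given here, no measured pair in the set carries this change, so its size cannot be read from the present data. The step is expected to be small, a 1.5-fold higher number from compound 2 to compound 3 (0.17 log units; within the scatter), within the usual scatter or leaning slightly toward weaker inhibition. Compound 3 is estimated at 400 nM in this assay, with a range from 150 nM to 1200 nM.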

Compound 3, half-maximal inhibitory concentration: 520 nM
The estimate for compound 3 lay 1.3-fold (0.11 log units) below the measured number, within the range that was stated.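

In this assay the change gives a 1.9-fold higher number from compound 2 to compound 3 (0.28 log units; within the scatter), so hydroxy in place of hydrogen on a saturated chain carbon bound to a carbonyl carbon leaves the two compounds within the scatter of each other. For the compounds shown here, this is the first measured pair at this position, and on this read-out acetyl and (hydroxymethyl)carbonyl cannot be told apart. Both ends of the step are numbers, so no limit cuts the comparison short, unlike the one value that is only a limit: the limit of > 80000 nM in this assay, at which 1 of the 3 values shown sits.

A single step at a single position does not show how far this result extends. As far as these compounds go, whether an amine or a carboxylic acid on the same carbon, or a longer chain in place of acetyl, would also stay within the scatter of compound 2 remains open.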